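The source may hold more compounds than are shown below. What is called first, only, known or untested is meant among the compounds shown, and "the series" means these compounds.

Working notes on the series.

Three compounds share a common core and have been run in an ADME assay (liver) for metabolic stability, with Liver microsome (Homo sapiens) as the target, using microsomes; on this read-out lower numbers stand for slow clearance and higher numbers for fast clearance. Compound 1 `c1ccc(CNc2nnc(-c3c[nH]c4ncccc34)o2)cc1` gives 31 mL.min-1.g-1. Compound 2 `Fc1ccccc1CNc1nnc(-c2c[nH]c3ncccc23)o1` gives 32 mL.min-1.g-1. The step of a 1.0-fold higher number from compound 1 to compound 2 (0.01 log units; within the scatter) rests on one change, (fluoro in place of hydrogen on an aromatic carbon). Compound 3 `Fc1ncccc1[C@H](Nc1nnc(-c2c[nH]c3ncccc23)o1)C1CC1` gives 21 mL.min-1.g-1; its separation from compound 1 and compound 2 is within the scatter, so no order among the three is read. The difference between the core of compound 3 and the core of compound 1 is not broken down here.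

Compound 4 `Fc1cnc2[nH]cc(-c3nnc(N[C@@H](c4cccnc4F)C4CC4)o3)c2c1` is not yet measured. It differs from compound 3 by fluoro in place of hydrogen on an aromatic carbon. Among the compounds with values here, this is the same kind of change as the one from compound 1 to compound 2, but not the same: there the fluoro entered on an aromatic carbon of a six-membered aromatic ring of carbon only, ortho to a large group, whereas here it enters on an aromatic carbon of a six-membered aromatic ring with 1 nitrogen, part of a fused or bridged system of two rings, two atoms from the ring nitrogen, meta to a fused ring and para to a fused ring. Within the data shown here, the only precedent for fluoro in place of hydrogen in this set is a 1.0-fold higher number from compound 1 to compound 2 (0.01 log units; within the scatter), which sat within the scatter. On that basis the step from compound 3 to compound 4 in this assay is expected to be small, a 1.2-fold lower number from compound 3 to compound 4 (0.07 log units; within the scatter), set beside the earlier one. Compound 4 is therefore estimated at 18 mL.min-1.g-1 in this assay, with a range from 9 mL.min-1.g-1 to 36 mL.min-1.g-1.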

Compound 4, intrinsic clearance in microsomes: < 14 mL.min-1.g-1
Compound 4: only a limit was reported (the forecaster's own chance of this, stated with the estimate: 5%); middle value at least 1.2-fold (0.10 log units) from the limit.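

In this assay, fluoro in place of hydrogen on an aromatic carbon can now be read on two cores, and the two readings stand as follows: the same change on two cores in this assay, a 1.0-fold higher number (0.01 log units; within the scatter) from compound 1 to compound 2 and an at least 1.5-fold lower number (0.17 log units; that floor lies within the scatter) from compound 3 to compound 4; the limit leaves it open whether they differ

The reading for compound 4 is a limit of the assay and not a number: compound 4 stands at < 14 mL.min-1.g-1.

The step is an at least 1.5-fold lower number from compound 3 to compound 4 (0.17 log units; that floor lies within the scatter), and it gives only a floor, so the series shows neither that the change carries unaltered from one core to another nor that its size depends on the core, and the fluoro also enters on a different ring in each pair, a six-membered aromatic ring of carbon only in compound 2 and a six-membered aromatic ring with 1 nitrogen in compound 4.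

The compounds shown leave open how a chloro, a nitrile or an amine would read on the same aromatic carbon of compound 3. Also open, going by these compounds, is how fluoro would read on that aromatic carbon of the core of compound 1, a pair that would set the change at one place on two cores.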